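Replacing the dimethylpyrazolyl group with an oxazolyl group

The compounds below may be only part of what the source reports. "The series", "measured", "known", "first", "only" and "open" are said of these compounds alone.

Half-lives measured in an ADME assay (liver, Mus musculus) for metabolic stability, using microsomes (on this read-out higher numbers stand for a longer-lived compound and lower numbers for a shorter-lived compound), are as follows
Compound 1 `C=CC(=O)Nc1cccc(CNc2nc(Nc3cc(F)c(N4CCN(C(C)=O)CC4)c(F)c3)ncc2Cl)c1` gives 0.0567 h
Compound 2 `C=CC(=O)Nc1cccc(CNc2nc(Nc3cn(C)nc3C)ncc2Cl)c1` gives 0.138 h

Of these two compounds, compound 2 has the higher number, and its gap to compound 1 lies beyond the usual scatter. Compound 3 `C=CC(=O)Nc1cccc(CNc2nc(Nc3cnoc3)ncc2Cl)c1` carries 1,2-oxazol-4-yl in place of 1,3-dimethyl-1H-pyrazol-4-yl on a nitrogen on an aromatic ring and has not yet been measured. For the measured compounds named here, no measured pair shows this change, so the data offer no direct guide to it. The expected step of a 1.1-fold higher number from compound 2 to compound 3 (0.04 log units; within the scatter) is estimated to stay within the scatter, with no firm direction. Compound 3 is expected at 0.15 h in this assay with an estimated range of 0.06 h to 0.38 h for its half-life.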

Compound 3, half-life: 0.0583 h
Compound 3: middle estimate off by 2.6-fold (0.41 log units), on the high side, and the stated range ends above it.
By their numbers in this assay, from the lowest: compounds 1 and 3 (each within the scatter of the next); then compound 2.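

In this assay, the group on this nitrogen on an aromatic ring matters: 1,2-oxazol-4-yl in place of 1,3-dimethyl-1H-pyrazol-4-yl gives a 2.4-fold lower number from compound 2 to compound 3 (0.37 log units; beyond the scatter). For the compounds shown here, this is the first single-place step available here, and it arises even though both groups are five-membered aromatic rings with 2 hetero atoms and the same donor and acceptor counts. Nothing measured here explains the step. The compounds shown leave open whether the step follows the ring itself or its two methyl groups. An unsubstituted pyrazolyl group at this place would help separate the two.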